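Amino Alcohols with Two Chain Lengths: Expecting Compound 4

A few compounds are considered here, and "the series" means these few. Any claim that something is new, unique, unknown or untested is made for them only; others in the source may bear on it.

Measured in a functional assay on T47D cells (Homo sapiens) for antiproliferative activity, read by sulforhodamine B assay, with a stated time of 48 h; on this read-out lower numbers stand for stronger inhibition of growth and higher numbers for weaker inhibition of growth:
compound 1, `CCCCCCCCC[C@@H](O)[C@H](C)N`, gives 12000 nM
compound 2, `CCCCCCCCC[C@@H](O)[C@@H](N)[C@@H](C)CC`, gives 14000 nM
compound 3, `CCCCCCCCCCCCCCC[C@@H](O)[C@H](C)N`, gives 900 nM

Compound 4, `CCCCCCCCCCCCCCC[C@@H](O)[C@@H](N)[C@@H](C)CC`, has not yet been measured. It differs from compound 3 by sec-butyl in place of methyl on a saturated chain carbon bound to an amine nitrogen and a saturated chain carbon. The same change, made once before between measured compounds, is compound 1 to compound 2: sec-butyl in place of methyl on a saturated chain carbon bound to an amine nitrogen and a saturated chain carbon. Its place is identical in both pairs, so this is the same change. In this assay it gave a 1.2-fold higher number from compound 1 to compound 2 (0.07 log units; within the scatter). The two cores differ by hexyl in place of hydrogen on a saturated chain carbon, ten or more bonds along the chain from an oxygen on a saturated carbon, and that step gave a 13-fold lower number from compound 1 to compound 3 (1.12 log units; beyond the scatter), making compound 3 the strongest of the three measured.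

The step from compound 3 to compound 4 is expected to be small, about a 1.2-fold higher number from compound 3 to compound 4 (0.09 log units; within the scatter), because a 1.2-fold higher number from compound 1 to compound 2 (0.07 log units; within the scatter) stayed within the scatter. Compound 4 is therefore estimated at 1100 nM, with a likely range from 450 nM to 2800 nM.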

Compound 4, concentration for 50% growth inhibition: 17000 nM
Beside the measured number, compound 4's estimate is 15-fold (1.19 log units) below it; measured number above the stated range.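

The swap of methyl for sec-butyl does not carry over unchanged from one core to another in this series, since on the core of compound 3 it gave a 19-fold higher number from compound 3 to compound 4 (1.28 log units; beyond the scatter) and so departs from its earlier size: the same change on two cores in this assay, a 1.2-fold higher number (0.07 log units; within the scatter) from compound 1 to compound 2 and a 19-fold higher number (1.28 log units; beyond the scatter) from compound 3 to compound 4, 16-fold (1.21 log units) apart, beyond the scatter of two such steps. Read the other way, adding hexyl to the core of compound 2 gave a 1.2-fold higher number from compound 2 to compound 4 (0.08 log units; within the scatter) and so does not repeat the earlier step from the core of compound 1: the same change on two cores in this assay, a 13-fold lower number (1.12 log units; beyond the scatter) from compound 1 to compound 3 and a 1.2-fold higher number (0.08 log units; within the scatter) from compound 2 to compound 4, 16-fold (1.21 log units) apart, beyond the scatter of two such steps. The two changes therefore depend on each other in these four compounds, but this does not show why, or whether the same holds beyond them.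

Going by these compounds, whether ethyl or isopropyl in place of methyl behaves like methyl or like sec-butyl on the core of compound 3 remains open. So does the effect of sec-butyl with a longer chain.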